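Series notes: fluoro step on the distal phenyl

The compounds below may be only part of what the source reports. "The series", "measured", "known", "first", "only" and "open" are said of these compounds alone.

Measured so far:
compound 1 `N=C(N)c1ccc(/N=N/Nc2ccccc2C#Cc2ccccc2)cc1` — 8100 nM
compound 2 `N=C(N)c1ccc(/N=N/Nc2cccc(C#Cc3ccccc3)c2)cc1` — 6500 nM
compound 3 `N=C(N)c1ccc(/N=N/Nc2ccccc2C#Cc2ccc(F)cc2)cc1` — 9500 nM

All three numbers come from a functional assay on OVCAR-3 cells (Homo sapiens) for antiproliferative activity, read by WST assay, with a stated time of 72 h; on this read-out lower numbers stand for stronger inhibition of growth and higher numbers for weaker inhibition of growth. In this assay compound 1 gives 8100 nM, compound 2 gives 6500 nM and compound 3 gives 9500 nM; the three lie within the scatter of one another, so no order among them is read.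

Compound 3 differs from compound 1 by fluoro in place of hydrogen on an aromatic carbon, and that change gave a 1.2-fold higher number from compound 1 to compound 3 (0.07 log units; within the scatter). The same change, at a place described in the same words, takes compound 2 to compound 4 `N=C(N)c1ccc(/N=N/Nc2cccc(C#Cc3ccc(F)cc3)c2)cc1`: fluoro in place of hydrogen on an aromatic carbon. Compound 2 and compound 1 share the same atoms joined differently; the difference between the two cores is not broken down here.

The change has been read only once among measured pairs, and there it stayed within the scatter. On that basis compound 4 is expected to sit close to compound 2, with an expected step of a 1.2-fold higher number from compound 2 to compound 4 (0.08 log units; within the scatter) in this assay, resting on a 1.2-fold higher number from compound 1 to compound 3 (0.07 log units; within the scatter). For compound 4 the value in this assay is estimated at 7800 nM, expected to fall between 4500 nM and 14000 nM.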

Compound 4, concentration for 50% growth inhibition: 5000 nM
The estimate for compound 4 lay 1.6-fold (0.19 log units) above the measured number; the measured number falls inside the stated range.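

In this assay, the fluoro change on the second core gives a 1.3-fold lower number from compound 2 to compound 4 (0.11 log units; within the scatter), and the two readings of this change do not differ: the same change on two cores in this assay, a 1.2-fold higher number (0.07 log units; within the scatter) from compound 1 to compound 3 and a 1.3-fold lower number (0.11 log units; within the scatter) from compound 2 to compound 4, 1.5-fold (0.18 log units) apart, within the scatter of two such steps

On both cores, then, phenyl to 4-fluorophenyl leaves the number within the scatter, and for these two pairs the change can be carried from one core to the other without a readable step. This does not fix a size or direction for the change: the opposite directions of the two steps carry no meaning, and two pairs say nothing about cores outside compound 1 and compound 2.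

Left open is whether a group other than fluoro at the same place, such as an amine, a carboxylic acid or a methoxy group, would give a step beyond the scatter on either core. Also open, going by these compounds, is whether the two cores would still read alike with such a group in place of the hydrogen.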